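Swapping the sulfur substituent in an aminophenyl benzamide series

The source may report more compounds than this note shows. Statements on the series, on what has been measured and on what is new or still open speak of the compounds shown alone.

Compound 1 `COc1ccc(SCc2ccc(C(=O)Nc3ccccc3N)cc2)cc1` gives 90.1% in a functional assay on HCT-116 cells (Homo sapiens) for inhibition, read by CCK-8 assay, with a stated time of 72 h, tested at 8 uM; on this read-out lower numbers stand for less inhibition of growth and higher numbers for more inhibition of growth at the one concentration tested.
Compound 2 `Nc1ccccc1NC(=O)c1ccc(CSc2ccc(F)cc2)cc1` gives 90.6% in this assay.

On these two numbers compound 2 has the higher figure, but its step from compound 1, a number 0.5 percentage points higher from compound 1 to compound 2 (within the scatter), is too small to count as a difference, so both compounds simply sit at the same high level of growth inhibition.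

Compound 3 `Nc1ccccc1NC(=O)c1ccc(CSCCc2ccccc2)cc1` is not yet measured. It differs from compound 2 as follows: phenethyl in place of 4-fluorophenyl on a sulfur. Going by the values given here, the only measured step, a number 0.5 percentage points higher from compound 1 to compound 2 (within the scatter), concerns an exchange of one small group on the aromatic ring and says nothing about replacing that whole aromatic ring by a chain-linked one, so no measured step bears directly on this change. With both measured compounds near the top of the scale, compound 3 is expected to stay high, with a number 6.6 percentage points lower from compound 2 to compound 3 (within the scatter) a small downward step that could reach beyond the scatter. The estimate for compound 3 in this assay is 84%, within 62% to 96%.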

Compound 3, percent growth inhibition at one concentration: 81.3%
The estimate for compound 3 lay 2.7 percentage points above the measured number; the measured number falls inside the stated range.
By their numbers in this assay, from the lowest: compounds 3, 1 and 2 (each within the scatter of the next).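

In this assay, going by these compounds alone, phenethyl in place of 4-fluorophenyl on the sulfur gives a number 9.3 percentage points lower from compound 2 to compound 3 (within the scatter), and phenethyl in place of 4-methoxyphenyl gives a number 8.8 percentage points lower from compound 1 to compound 3 (within the scatter), so neither step separates compound 3 from the earlier compounds. Compound 1 and compound 2 differ only in a small group on the aromatic ring, whereas compound 3 shows that the whole substituent on the sulfur can be exchanged for phenethyl with no step beyond the usual scatter. No measured data here offer an explanation for this result.

From the compounds shown here alone, it remains open whether this sulfur can carry a group with no aromatic ring, such as an amine or a carboxylic acid, or a longer chain ending in phenyl. Readings at a single concentration also leave open whether compound 1, compound 2 and compound 3 would separate at lower concentrations.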